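Tolerance Holds as a Ring Amine Gains a Difluorobenzyl

The source may report more compounds than this note shows. Statements on the series, on what has been measured and on what is new or still open speak of the compounds shown alone.

Compound 1 `COC(=O)C[C@H](NC(=O)OC(C)(C)C)C(=O)N(Cc1ccc(F)cc1)C1(C(=O)NCc2ccccc2)CCNCC1` was tested in an ADME assay on MDCK cells (Canis lupus familiaris) for cytotoxicity, read by microscopy, with a stated time of 72 h (a higher number here means that more compound is tolerated, a lower number that less compound is tolerated), and gave 100000 nM. Compound 2 `CC[C@H](C)[C@H](NC(=O)OCc1ccccc1)C(=O)N(C1CC1)C1(C(=O)NC(C)(C)C)CCN(Cc2ccccc2)CC1` is a companion with a different amino acid residue and a benzyl group on the ring amine; in this assay compound 2 gives 100000 nM. Compound 1 thus stands level with compound 2 at the digits recorded, the two values lying within the scatter of each other, so no order between them can be stated.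

Compound 3 `COC(=O)C[C@H](NC(=O)OC(C)(C)C)C(=O)N(Cc1ccc(F)cc1)C1(C(=O)NCc2ccccc2)CCN(Cc2cc(F)cc(F)c2)CC1` has not yet been measured. It differs from compound 1 in one place: 3,5-difluorobenzyl in place of hydrogen on an amine nitrogen in a ring. Going by the values given here, no pair of measured compounds that differ in exactly one place is available, so the size of this step cannot be read from a measured precedent. Since compound 2, which already carries a benzyl group on its ring amine, gives 100000 nM, the account expects no step beyond the scatter, with only a modest lean toward less tolerance. Compound 3 is therefore estimated at 80000 nM, with a range from 30000 nM to 100000 nM. The expected step is a 1.3-fold lower number from compound 1 to compound 3 (0.10 log units; within the scatter).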

Compound 3, minimum cytotoxic concentration: 100000 nM
Compound 3: the middle estimate sits 1.3-fold (0.10 log units) below what was measured; the range from low to high includes it.
By their numbers in this assay, from the lowest: compounds 1, 2 and 3 (each within the scatter of the next).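

In this assay, going by these compounds alone, the change from a hydrogen to 3,5-difluorobenzyl on the amine nitrogen in a ring shows no change at the digits printed from compound 1 to compound 3 (within the scatter) and is the first step here that can be read at a single place, since the two earlier compounds differ from each other in more than one. This position therefore takes a group of 9 heavy atoms, including one six-membered aromatic ring of carbon only, with no shift in the tolerated concentration on the core of compound 1. The compounds shown offer no evidence on why this substitution leaves the read-out unchanged.

Within the data shown here, this single step covers only one group at this nitrogen, so it remains open whether a small methyl, a benzyl bearing a carboxylic acid or an amine, or an acetyl group on the same nitrogen would also leave the number unchanged. Among these compounds, it is also open whether 3,5-difluorobenzyl would behave the same way on a core with a different amino acid residue, as no such single-place pair is available.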